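An ethyl group added to compound 1

A few compounds are considered here, and "the series" means these few. Any claim that something is new, unique, unknown or untested is made for them only; others in the source may bear on it.

Measured in an in vitro ADME assay on microsomes from liver (Rattus norvegicus) for metabolic stability; on this read-out higher numbers stand for fast clearance and lower numbers for slow clearance:
- Compound 1 `Cc1ccc(Cn2c(=O)[nH]c3c(N)nc(-c4ncco4)cc32)cn1`: < 8.5 mL.min-1.g-1
- Compound 2 `Cc1nc(Cn2c(=O)[nH]c3c(N)nc(C(F)(F)F)cc32)co1`: < 10 mL.min-1.g-1
- Compound 3 `CN1CCN(c2ccc(Cn3c(=O)[nH]c4c(N)nc(C(F)(F)F)cc43)cn2)CC1`: 46 mL.min-1.g-1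

Compound 1 gives < 8.5 mL.min-1.g-1, and this reading is a limit, not a number. For compound 2, the reading < 10 mL.min-1.g-1 is also a limit. Compound 3 alone gives a number, 46 mL.min-1.g-1. Compound 4 `CCc1coc(-c2cc3c([nH]c(=O)n3Cc3ccc(C)nc3)c(N)n2)n1` keeps the core of compound 1 but changes 1,3-oxazol-2-yl to 4-ethyl-1,3-oxazol-2-yl (ethyl in place of hydrogen on an aromatic carbon). Ethyl takes the place of hydrogen on an aromatic carbon. For the measured compounds named here, no measured pair shows what such a change does. A modest rise in this assay is expected, perhaps not beyond the scatter. The expected size is an at least 1.6-fold higher number from compound 1 to compound 4 (0.21 log units; that floor lies within the scatter). For compound 4 the estimate is 14 mL.min-1.g-1, with a range of 6 mL.min-1.g-1 to 32 mL.min-1.g-1.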

Compound 4, intrinsic clearance in microsomes: < 8.5 mL.min-1.g-1
Compound 4 was reported as a limit (the forecaster's own chance of this, stated with the estimate: 35%); middle value at least 1.6-fold (0.21 log units) from the limit.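

Compound 1 and compound 4 both give only a limit in this assay, and no step between them can be read: the limit of < 8.5 mL.min-1.g-1 in this assay, at which 2 of the 4 values shown sit.

The compounds shown leave open whether ethyl in place of hydrogen on this aromatic carbon changes clearance at all.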